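The compounds below may be only part of what the source reports. "The series", "measured", "known", "first", "only" and "open" are said of these compounds alone.

Among the measured compounds shown here, the three compounds measured so far share one core and differ only in the groups at its two ends. Compound 1 `CC(=O)Nc1ccc(Nc2nccc(-c3cccnc3)n2)cc1` gives 3600 nM in a functional assay for inhibition, with Homo sapiens as the target; a higher number here means a weaker inhibitor, a lower number a stronger inhibitor. Compound 2 `c1ccc(-c2ccnc(Nc3ccc(-n4ccnc4)cc3)n2)nc1` gives 1400 nM in this assay, and compound 3 `c1cncc(-c2ccnc(Nc3ccc(-n4ccnc4)cc3)n2)c1` gives 1300 nM. Among these three numbers compound 2 stands second highest: compound 3 is nearest to it, with a 1.1-fold lower number from compound 2 to compound 3 (0.03 log units; within the scatter), a gap within the scatter, while compound 1 lies furthest from it, its value beyond the scatter of that of compound 2.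

Compound 4 `CC(=O)Nc1ccc(Nc2nccc(-c3ccccn3)n2)cc1` has not yet been measured. It differs from compound 2 in one place: acetamido in place of 1H-imidazol-1-yl on an aromatic carbon. The measured step that bears on this change is the one where the same two groups are exchanged in the opposite direction, a 2.8-fold lower number from compound 1 to compound 3 (0.44 log units; beyond the scatter). The exchange of pyridin-2-yl for pyridin-3-yl stayed within the scatter, as a 1.1-fold lower number from compound 2 to compound 3 (0.03 log units; within the scatter) shows, so compound 4 is expected to sit close to compound 1. The step from compound 2 to compound 4 is therefore expected to raise the number by about the size of the earlier step, a 2.6-fold higher number from compound 2 to compound 4 (0.42 log units; beyond the scatter). Compound 4 is estimated to give 3700 nM in this assay, with a range from 1800 nM to 7500 nM.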

Compound 4, half-maximal inhibitory concentration: 1500 nM
Estimate against measurement, compound 4: 2.5-fold (0.39 log units) above; measured number below the stated range.
By their numbers in this assay, from the lowest: compounds 3, 2 and 4 (each within the scatter of the next); then compound 1.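

With pyridin-2-yl on the shared core, acetamido in place of 1H-imidazol-1-yl leaves the number in this assay essentially unmoved, a 1.1-fold higher number from compound 2 to compound 4 (0.03 log units; within the scatter), so the step seen for this exchange with pyridin-3-yl does not carry over, though the two steps cannot be told apart: the same change on two cores in this assay, a 2.8-fold lower number (0.44 log units; beyond the scatter) from compound 1 to compound 3 and a 1.1-fold lower number (0.03 log units; within the scatter) from compound 4 to compound 2, 2.6-fold (0.41 log units) apart, within the scatter of two such steps

With acetamido held in place, the choice of pyridine now gives a step beyond the scatter, a 2.4-fold lower number from compound 1 to compound 4 (0.38 log units; beyond the scatter), which it did not give with 1H-imidazol-1-yl, and here too the two steps cannot be told apart: the same change on two cores in this assay, a 1.1-fold lower number (0.03 log units; within the scatter) from compound 2 to compound 3 and a 2.4-fold higher number (0.38 log units; beyond the scatter) from compound 4 to compound 1, 2.6-fold (0.41 log units) apart, within the scatter of two such steps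

Compound 1 alone therefore stands apart from the other three, and this pattern of four does not establish that the two ends depend on each other.

Among the compounds shown here, whether that dependence is real rests on the single value of compound 1, and a repeat of that value or a further pair of compounds would be needed to settle it. Also open, from the compounds shown here alone, is how this position responds to a group such as an amine or a carboxylic acid in place of acetamido, and how the other end responds to pyridin-4-yl.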